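This account rests on a few compounds, and the source may have more. Where it says the series, first, only, none or still open, it means among the compounds named here.

Measured compounds in an assay on isolated protein for inhibition of histone deacetylase 8 (Homo sapiens), with a stated time of 1 h; on this read-out lower numbers stand for stronger inhibition and higher numbers for weaker inhibition:
- compound 1, `O=C(COc1ccc2cc(/C=C3/SC(=O)NC3=O)ccc2c1)Nc1ccc(Br)cc1` — compound 1 gives 16000 nM
- compound 2, `COc1cccc(NC(=O)COc2ccc3cc(/C=C4/SC(=O)NC4=O)ccc3c2)c1` — compound 2 gives 7600 nM
- compound 3, `Cc1cccc2sc(NC(=O)COc3ccc4cc(/C=C5/SC(=O)NC5=O)ccc4c3)nc12` — compound 3 gives 5800 nM

Compound 1 stands at the highest number of the three. Its two neighbours in the set both replace the 4-bromophenyl on the amide-type nitrogen and both move downwards: a 2.1-fold lower number from compound 1 to compound 2 (0.32 log units; beyond the scatter) and a 2.8-fold lower number from compound 1 to compound 3 (0.44 log units; beyond the scatter), each a modest step and each beyond the scatter. Between the two replacements themselves the gap is small: a 1.3-fold lower number from compound 2 to compound 3 (0.12 log units; within the scatter), within the scatter.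

Compound 4, `O=C(COc1ccc2cc(/C=C3/SC(=O)NC3=O)ccc2c1)Nc1ccc(Cl)c(Cl)c1`, is the next variation on the same position. Difference from compound 1: 3,4-dichlorophenyl in place of 4-bromophenyl on an amide-type nitrogen. Both measured steps bear on it in that they change the same group at the same place, but neither entering group is a halogen-bearing six-membered aromatic ring of carbon only, so the analogy is loose. The two measured steps from compound 1 were modest, and compound 4 stays closer in kind to compound 1 than compound 2 or compound 3 does, so the step of a 1.5-fold lower number from compound 1 to compound 4 (0.16 log units; within the scatter) is expected to be small, at most a modest lowering and possibly within the scatter. Compound 4 is therefore estimated at 11000 nM, with a range from 4500 nM to 28000 nM.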

Compound 4, half-maximal inhibitory concentration: > 50000 nM
Compound 4: a limit, no number; the forecaster's own chance of this, stated with the estimate: 5%; middle value at least 4.5-fold (0.65 log units) from the limit.
By their numbers in this assay, from the lowest: compounds 3 and 2 (each within the scatter of the next); then compound 1. At a limit, above all of these: compound 4.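

In this assay compound 4 sits at a limit of the assay and has no number: the limit of > 50000 nM in this assay, at which 1 of the 4 values shown sits. The position is therefore more sensitive than the earlier modest steps suggested, with the change from 4-bromophenyl to 3,4-dichlorophenyl giving an at least 3.1-fold higher number from compound 1 to compound 4 (0.49 log units; beyond the scatter), while the two other amide-nitrogen groups give an at least 8.6-fold higher number from compound 3 to compound 4 (0.93 log units; beyond the scatter) and an at least 6.5-fold higher number from compound 2 to compound 4 (0.81 log units; beyond the scatter). Compounds 1 and 4 both carry one six-membered aromatic ring of carbon only, with no hydrogen-bond donors or acceptors on the group, yet their step lies beyond the scatter, so these shared counts do not settle the read-out at this position, and a close change in the group can matter more than the larger replacements seen in compounds 2 and 3.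

From the compounds shown here alone, the true size of all three steps stays open, as compound 4 gives only a limit. The compounds shown also cannot separate the effect of a second halogen from that of chlorine replacing bromine, and they do not show how 4-chlorophenyl, or a phenyl ring bearing an amine or a carboxylic acid, would read out here.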